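Swapping a Pentyl Chain for a Furan-Bearing Group

This account rests on a few compounds, and the source may have more. Where it says the series, first, only, none or still open, it means among the compounds named here.

Compound 2 `CCCCCNC(=O)/N=C(\N)NCCCc1sc(N)nc1C` gives 4.47 nM in an assay on membranes from Sf9 cells for displacement of a labelled ligand from histamine H2 receptor (Homo sapiens), read by scintillation counting, with a stated time of 60 min (a higher number here means a weaker inhibitor, a lower number a stronger inhibitor), the lowest of the three numbers in hand. Compound 1 `Cc1ccc(CC(C)CNC(=O)/N=C(\N)NCCCc2sc(N)nc2C)cc1` gives 72.4 nM in this assay, well beyond the scatter above compound 2, and compound 3 `CCCCCCNC(=O)/N=C(\N)NC1CCc2nc(N)sc2C1` gives 1120 nM in this assay, further still. Compound 4 `Cc1nc(N)sc1CCCN/C(N)=N/C(=O)NC(C)c1ccco1` has not yet been measured in this assay. It differs from compound 2 in one place: 1-(furan-2-yl)ethyl in place of pentyl on an amide-type nitrogen. For the measured compounds named here, no measured pair shows this exact change. An upward step beyond the scatter is nevertheless expected for compound 4: a 5.6-fold higher number from compound 2 to compound 4 (0.75 log units; beyond the scatter). This rests on compound 1, which carries a different group on that nitrogen and gave 72.4 nM. For compound 4 the expected value is 25 nM, within a range from 6 nM to 120 nM.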

Compound 4, inhibition constant: 31.6 nM
The estimate for compound 4 lay 1.3-fold (0.10 log units) below the measured number; low and high end bracket the measured number.
By their numbers in this assay, from the lowest: compound 2; then compound 4; then compound 1; then compound 3.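

For the compounds shown here, replacing pentyl with 1-(furan-2-yl)ethyl on the amide-type nitrogen gives the first direct reading of this position: a 7.1-fold higher number from compound 2 to compound 4 (0.85 log units; beyond the scatter) in this assay. The position therefore responds to this change, yet it accepts a group bearing a five-membered aromatic ring, since compound 4 still gives 31.6 nM. Nothing measured here explains the step.

The compounds shown leave open whether the ring or its oxygen accounts for the step. From the compounds shown here alone, how 1-(thiophen-2-yl)ethyl, with sulfur in place of that oxygen, would compare on this nitrogen also remains open.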